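The source may report more compounds than this note shows. Statements on the series, on what has been measured and on what is new or still open speak of the compounds shown alone.

Among the measured compounds shown here, compound 2 `COc1ccc(N2CCn3c2n[nH]c(=O)c3=O)cc1` gives the higher of the two numbers measured so far: in a functional assay on T47D cells (Homo sapiens) for cytotoxicity, with a stated time of 72 h, tested at 50 ug/mL (a higher number here means a stronger effect of the compound at the concentration tested, a lower number a weaker effect), compound 2 gives 21%, while compound 1 `N=c1c(=O)[nH]nc2n1CCN2c1ccccc1Cl` in this assay gives 0%, a gap beyond the scatter. Compound 3 `Cc1ccc(N2CCn3c2n[nH]c(=O)c3=O)cc1` differs from compound 2 in one place: methyl in place of methoxy on an aromatic carbon. For the measured compounds named here, no step between measured compounds shows what such a swap does here, so the change is expected to move this assay by no more than the scatter in either direction, a step of a number 3 percentage points lower from compound 2 to compound 3 (within the scatter) from compound 2. Compound 3 is expected to give 18%, within 0% to 38%.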

Compound 3, a percentage reported as inhibition, at one concentration (the size of the read-out at that concentration, not a potency): 22%
Estimate against measurement, compound 3: 4 percentage points below; measured number inside the range.
By their numbers in this assay, from the lowest: compound 1; then compounds 2 and 3 (each within the scatter of the next).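

Methyl in place of methoxy on this aromatic carbon, para to a large group, gives a step of a number 1 percentage points higher from compound 2 to compound 3 (within the scatter) in this assay. This first direct comparison at this position shows that the oxygen of methoxy can leave without a change beyond the scatter, so these two groups cannot be told apart here. No measured evidence bears on why this is so. Still open, on these data alone, is whether a larger change at this position, such as an amine, a carboxylic acid or a longer chain, would move the number beyond the scatter.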